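The source may hold more compounds than are shown below. What is called first, only, known or untested is meant among the compounds shown, and "the series" means these compounds.

Three sulfonamides with a basic amine in the chain have been measured in a functional assay on MIA PaCa-2 cells (Homo sapiens) for inhibition, read by MTT assay, with a stated time of 72 h; a higher number here means a weaker inhibitor of growth, a lower number a stronger inhibitor of growth. Compound 1 `COc1ccc(CNCCCNS(=O)(=O)c2cc(C(F)(F)F)cc(C(F)(F)F)c2)cc1OC` gives 2800 nM in this assay. Compound 2 `O=S(=O)(NCCCCCCNCc1ccc(Br)cc1)c1c(Cl)cccc1Cl` gives 14700 nM in this assay, and compound 3 `O=S(=O)(NCCCCCCNCc1ccc(Br)cc1)c1cc(C(F)(F)F)cc(C(F)(F)F)c1` gives 2970 nM in this assay. Compound 1 therefore carries the lowest of the three numbers, but compound 3 sits so close that the two values fall within the usual scatter of each other, while compound 2 lies clearly further away, beyond that scatter.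

Compound 4 `O=S(=O)(NCCCNCc1ccc(Cl)cc1)c1cc(C(F)(F)F)cc(C(F)(F)F)c1` has not yet been measured in this assay. It differs from compound 1 in one place: 4-chlorophenyl in place of 3,4-dimethoxyphenyl on a saturated chain carbon bound to an amine nitrogen. The rest of the molecule, the bis(trifluoromethyl)phenyl sulfonamide and the three-carbon chain carrying the amine, is kept as in compound 1.

Going by the values given here, no step between two measured compounds isolates this exchange, so the expectation rests on what compound 1 and compound 3 show: a halogen-bearing benzyl group on the amine in compound 3 returns a number close to that of compound 1. The step of a 1.1-fold higher number from compound 1 to compound 4 (0.03 log units; within the scatter) is therefore expected to be small, in no clear direction, and probably not beyond the scatter. For compound 4 the estimate in this assay is 3000 nM, with a range from 1200 nM to 8000 nM.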

Compound 4, concentration for 50% growth inhibition: 2800 nM
Estimate against measurement, compound 4: 1.1-fold (0.03 log units) above; the measured number falls inside the stated range.
By their numbers in this assay, from the lowest: compounds 1, 4 and 3 (each within the scatter of the next); then compound 2.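

In this assay, going by these compounds alone, this is the first comparison that changes only the group at this place, on a saturated chain carbon bound to an amine nitrogen, and exchanging 3,4-dimethoxybenzyl for 4-chlorobenzyl gives no change at the digits printed from compound 1 to compound 4 (within the scatter). With the bis(trifluoromethyl)phenyl sulfonamide and three-carbon chain held constant, the two methoxy groups can therefore be replaced by a single chlorine, on a smaller group with no hydrogen-bond acceptors, without a change that can be told from ordinary assay variation. This shows tolerance for this one exchange, not for changes at this place in general, and no measurement shown here accounts for the result.

Going by these compounds, it remains open whether an unsubstituted benzyl group, a pyridylmethyl group or a simple methyl group would give a similar number, and so whether the aromatic ring or any substituent on it matters here. Compound 3 differs from compound 4 in both its halogen and its chain, so a 4-bromobenzyl group on the three-carbon chain would be needed to separate those two changes.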